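Nitrile Added to an Inactive Core: What to Expect

The compounds below may be only part of what the source reports. "The series", "measured", "known", "first", "only" and "open" are said of these compounds alone.

Three compounds have been measured in an assay on membranes from brain for binding affinity to neutral cholesterol ester hydrolase 1 (Mus musculus), read by fluorescence, with stated times of 1 h and 30 min; a lower number here means a stronger inhibitor, a higher number a weaker inhibitor:

Compound 1, `O=C(NCc1ccc(OC(c2ccccc2)c2ccccc2)cc1)n1cccn1`: > 100000 nM
Compound 2, `N#Cc1cnn(C(=O)NCc2ccc(OC(c3ccccc3)c3ccccc3)cc2)c1`: > 100000 nM
Compound 3, `O=C(N1CCN(C(c2ccc(OCc3ccccc3)cc2)c2ccc(OCc3ccccc3)cc2)CC1)n1cccn1`: > 100000 nM

Each of these values is a limit of the assay, not a number. For compound 1 the result is a limit, > 100000 nM. For compound 2 the result is likewise a limit, > 100000 nM. For compound 3 too only a limit is recorded, > 100000 nM. The change from compound 1 to compound 2 is cyano in place of hydrogen on an aromatic carbon; its step, a step that the two limits leave unreadable from compound 1 to compound 2, cannot be read because of the limit of > 100000 nM in this assay, at which 3 of the 3 values shown sit.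

Compound 4, `N#Cc1cnn(C(=O)N2CCN(C(c3ccc(OCc4ccccc4)cc3)c3ccc(OCc4ccccc4)cc3)CC2)c1`, has not yet been measured. It differs from compound 3 by cyano in place of hydrogen on an aromatic carbon, the same change seen between compound 1 and compound 2. The difference between the core of compound 3 and the core of compound 1 is not broken down here.

The expectation for compound 4 rests on compound 3 giving only a limit, > 100000 nM, and on compound 2 also giving only a limit, > 100000 nM. The step from compound 3 to compound 4 is therefore expected to be a step that the limit leaves unreadable from compound 3 to compound 4. For compound 4 the estimate in this assay is 150000 nM, between 40000 nM and 600000 nM.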

Compound 4, half-maximal inhibitory concentration: > 100000 nM
Compound 4: a limit, no number (the forecaster's own chance of this, stated with the estimate: 90%); the middle value does not contradict the limit.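

In this assay compound 4 gives > 100000 nM, which is a limit and not a number. The change from compound 3 to compound 4 therefore gives no readable step, for this reason: the limit of > 100000 nM in this assay, at which 4 of the 4 values shown sit. From the compounds shown here alone, whether cyano in place of hydrogen alters inhibition on either core, and by how much, stays open.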